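Swapping the furan of compound 3 for a pyrazole

A few compounds are considered here, and "the series" means these few. Any claim that something is new, unique, unknown or untested is made for them only; others in the source may bear on it.

Measured so far:
Compound 1, `c1cnc(-c2ccccc2OCC2=NCCN2)nc1`: in a functional assay for activation of Alpha-1B adrenergic receptor (Homo sapiens), read by calcium flux (on this read-out lower numbers stand for an effect already at smaller amounts and higher numbers for an effect only at larger amounts of compound), compound 1 gives < 100000 nM, which is a limit of the assay and not a number.
Compound 2, `c1ccc(-c2cnccn2)c(OCC2=NCCN2)c1`: compound 2 gives 631 nM.
Compound 3, `c1ccc(-c2ccoc2)c(OCC2=NCCN2)c1`: compound 3 gives 5.01 nM.

Of the two numbers, compound 3 holds the lower one; its nearest neighbour is compound 2, and the pair is separated by a 130-fold lower number from compound 2 to compound 3 (2.10 log units; beyond the scatter).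

Compound 4, `c1ccc(-c2cc[nH]n2)c(OCC2=NCCN2)c1`, differs from compound 3 by 1H-pyrazol-3-yl in place of furan-3-yl on an aromatic carbon. Among the compounds with values here, the only readable step is a 130-fold lower number from compound 2 to compound 3 (2.10 log units; beyond the scatter), where a five-membered ring with one oxygen replaced a six-membered ring with two nitrogens. The steps a step that the limit leaves unreadable from compound 1 to compound 2 and a step that the limit leaves unreadable from compound 1 to compound 3 cannot be sized because of the limit (the limit of < 100000 nM in this assay, at which 1 of the 3 values shown sits). Compound 4 keeps the five-membered ring but brings in two nitrogens and a hydrogen-bond donor, so a moderate rise in the number is expected, a 10-fold higher number from compound 3 to compound 4 (1.00 log units; beyond the scatter). For compound 4 the estimate is 50 nM, with a range from 5 nM to 500 nM.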

Compound 4, half-maximal effective concentration: 79.4 nM
For compound 4 the middle estimate is 1.6-fold (0.20 log units) below the measured one; low and high end bracket the measured number.
By their numbers in this assay, from the lowest: compound 3; then compound 4; then compound 2.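

Keeping a five-membered aromatic ring on this aromatic carbon does not preserve the value in this assay: 1H-pyrazol-3-yl in place of furan-3-yl gives a 16-fold higher number from compound 3 to compound 4 (1.20 log units; beyond the scatter). Against pyrazin-2-yl, 1H-pyrazol-3-yl still gives a 7.9-fold lower number from compound 2 to compound 4 (0.90 log units; beyond the scatter), so the two five-membered rings shown both give lower numbers than that six-membered ring. Steps from compound 1 cannot be read because its value is a limit: the limit of < 100000 nM in this assay, at which 1 of the 4 values shown sits.

As far as these compounds go, the hetero atoms and the hydrogen-bond donor change together here, so their shares in the step stay open. Also open, from the compounds shown here alone, is how an amine or a carboxylic acid would read at this place.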